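Thiophene substituent swap on a fused imidazothiazole series

A few compounds are considered here, and "the series" means these few. Any claim that something is new, unique, unknown or untested is made for them only; others in the source may bear on it.

Measured so far in a functional assay on cells (Cancer cell lines, Homo sapiens) for inhibition; on this read-out higher numbers stand for weaker inhibition of growth and lower numbers for stronger inhibition of growth:
- compound 1 `Cc1cc(-c2nc3n(c2/C=N/NC(=N)N)CCS3)c(C)s1`: 18600 nM
- compound 2 `N=C(N)N/N=C/c1c(-c2cccs2)nc2sccn12`: 12000 nM

On these two numbers compound 1 stands next to compound 2, the gap between them lying within the scatter of repeated measurements, so no ordering between the two can be read from them. Among the compounds with values here, no pair differing in a single place has been measured, so no step size within this assay is known yet.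

Compound 3 `N=C(N)N/N=C/c1c(-c2cc(Cl)sc2Cl)nc2n1CCS2` has not been measured. It differs from compound 1 as follows: 2,5-dichlorothiophen-3-yl in place of 2,5-dimethylthiophen-3-yl on an aromatic carbon. Within the data shown here, with no comparable step measured, the step of a 1.6-fold lower number from compound 1 to compound 3 (0.19 log units; within the scatter) in this assay is expected to be small, not clearly beyond the scatter, in either direction. For compound 3 an estimate of 12000 nM in this assay is expected, within a range from 4000 nM to 40000 nM.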

Compound 3, concentration for 50% growth inhibition: 8710 nM
The estimate for compound 3 lay 1.4-fold (0.14 log units) above the measured number; low and high end bracket the measured number.
By their numbers in this assay, from the lowest: compounds 3, 2 and 1 (each within the scatter of the next, the first and the last beyond it).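

The first step measured in this series comes from this change: in this assay, 2,5-dichlorothiophen-3-yl in place of 2,5-dimethylthiophen-3-yl gives a 2.1-fold lower number from compound 1 to compound 3 (0.33 log units; beyond the scatter). This aromatic carbon of the shared core therefore takes either thiophene, with stronger inhibition of growth for the dichloro group, though the step is modest. Nothing available accounts for the step.

Still open, on these data alone, is whether a phenyl ring or a 2,5-dibromothiophen-3-yl group at this place would extend the step or reverse it. As far as these compounds go, whether the same swap gives a similar step on the core of compound 2 also remains open.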